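The source may hold more compounds than are shown below. What is called first, only, known or untested is meant among the compounds shown, and "the series" means these compounds.

Working notes on the series. Compound 1 `CCCCCCCCNC(=O)[C@@H](NC(=O)c1cc2ccccc2o1)[C@@H](C)O` and compound 2 `CCCCCCCCNC(=O)[C@@H](NC(=O)/C=C/c1ccccc1)[C@@H](C)O` share a core and differ only at the carbonyl carbon of the outer amide. In a functional assay on HepG2 cells (Homo sapiens) for cytotoxicity, read by MTT assay, with a stated time of 48 h (on this read-out lower numbers stand for stronger inhibition and higher numbers for weaker inhibition), compound 1 gives 81300 nM; in this assay compound 2 gives 55600 nM. For the measured compounds named here, the step of a 1.5-fold lower number from compound 1 to compound 2 (0.17 log units; within the scatter) is the only measured step and does not separate the two. Compound 2 therefore stands at the lower of the two numbers without being distinguishable from compound 1.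

Compound 3 `CCCCCCCCCCCCNC(=O)[C@@H](NC(=O)/C=C/c1ccccc1)[C@@H](C)O` keeps the core of compound 2 and alters the chain: butyl in place of hydrogen on a saturated chain carbon, eight bonds along the chain from an amide-type nitrogen. Going by the values given here, no measured step touches this part of the molecule; the one step on record concerns the other end of the core and offers no guide. The expectation is accordingly a small change at most. On that basis compound 3 is estimated at 40000 nM in this assay, within 15000 nM to 110000 nM, a step of a 1.4-fold lower number from compound 2 to compound 3 (0.14 log units; within the scatter) that is expected to stay close to the scatter.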

Compound 3, half-maximal inhibitory concentration: > 200000 nM
Compound 3 was reported as a limit; the forecaster's own chance of this, stated with the estimate: 5%; at least 5.0-fold (0.69 log units) between middle value and limit.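

Butyl in place of hydrogen on a saturated chain carbon, eight bonds along the chain from an amide-type nitrogen, moves the read-out in this assay by an at least 3.5-fold higher number from compound 2 to compound 3 (0.55 log units; beyond the scatter). This part of the molecule is therefore not silent, and here the added chain goes with weaker inhibition, which the step at the other end of the core could not show. The figure for compound 3 is a limit of the assay and not a number, so the step gives only a minimum size: the limit of > 200000 nM in this assay, at which 1 of the 3 values shown sits.

The compounds shown give one step along this chain, so they leave open whether the read-out changes gradually with length or only past a certain length. They also leave open how a shorter chain, or an amine or a carboxylic acid on this chain, would read.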